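Ester to acid on the coumarin-lipoyl triazole series

A few compounds are considered here, and "the series" means these few. Any claim that something is new, unique, unknown or untested is made for them only; others in the source may bear on it.

Compound 1 `O=C(CCCCC1CCSS1)NCc1cn(CCCOc2ccc3ccc(=O)oc3c2)nn1` gives 42.2% in a functional assay on PC-12 cells (Rattus norvegicus) for cytotoxicity, read by MTT assay, with stated times of 3 h and 2 h, tested at 20 uM; a lower number here means a weaker effect, a higher number a stronger effect of the compound at the concentration tested.
Compound 2 `CC(=O)c1cc2ccc(OCCCn3cc(CNC(=O)CCCCC4CCSS4)nn3)cc2oc1=O` gives 39.8% in this assay.
Compound 3 `CCOC(=O)c1cc2ccc(OCCCn3cc(CNC(=O)CCCCC4CCSS4)nn3)cc2oc1=O` gives 42.1% in this assay.

Compound 3 sits within the scatter of both others: a number 0.1 percentage points lower from compound 1 to compound 3 (within the scatter) and a number 2.3 percentage points higher from compound 2 to compound 3 (within the scatter). Compound 4 `O=C(CCCCC1CCSS1)NCc1cn(CCCOc2ccc3cc(C(=O)O)c(=O)oc3c2)nn1` differs from compound 3 by hydrogen in place of ethyl on an oxygen next to a carbonyl group. The two measured steps that touch the same position, a number 0.1 percentage points lower from compound 1 to compound 3 (within the scatter) and a number 2.3 percentage points higher from compound 2 to compound 3 (within the scatter), show that neither adding the ethoxycarbonyl group nor trading methyl for ethoxy on the carbonyl carbon moved the read-out beyond the scatter. Among the compounds with values here, no measured pair removes the ethyl from the ester oxygen, so the expectation rests on that flat picture alone. For compound 4 the step is therefore expected to be a number 1.1 percentage points lower from compound 3 to compound 4 (within the scatter), within the scatter. Compound 4 is estimated at 41%, between 30% and 52%.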

Compound 4, a percentage reported as activity, at one concentration (the size of the read-out at that concentration, not a potency): 66.8%
The estimate for compound 4 lay 25.8 percentage points below the measured number, outside the stated range (above it).
By their numbers in this assay, from the lowest: compounds 2, 3 and 1 (each within the scatter of the next); then compound 4.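

Of the groups shown at this place, only the carboxy group moves the number in this assay: hydrogen in place of ethyl on the oxygen gives a clear rise (a number 24.7 percentage points higher from compound 3 to compound 4 (beyond the scatter)), and the same holds for hydroxy in place of methyl on the carbonyl carbon (a number 27 percentage points higher from compound 2 to compound 4 (beyond the scatter)) and for carboxy in place of hydrogen on the aromatic carbon (a number 24.6 percentage points higher from compound 1 to compound 4 (beyond the scatter)). The position is therefore not indifferent, as the flat earlier steps had suggested. No evidence is available that bears on this rise. From the compounds shown here alone, what a primary amide, a tetrazole or a carboxylic acid on a longer chain would give at this place stays open.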